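The compounds below may be only part of what the source reports. "The series", "measured", "known", "first", "only" and "open" are said of these compounds alone.

Of the compounds shown here, two of this small set have so far been tested in an ADME assay on Huh-7 cells (Homo sapiens) for cytotoxicity; on this read-out lower numbers stand for higher toxicity in this test and higher numbers for lower toxicity in this test. Compound 1 `CN1CCN(CCNCc2cn(-c3ccc(F)cc3F)nc2-c2ccccc2)CC1` is known in this assay only by a limit: it gives > 20000 nM, which is a limit of the assay and not a number. Compound 2 `CN1CCN(CCCNCc2cn(-c3ccc(C(F)(F)F)cc3)nc2-c2ccc(Cl)cc2)CC1` gives 2500 nM in this assay. Compound 1 thus stands at the limit of > 20000 nM in this assay, at which 1 of the 2 values shown sits, whereas compound 2 stands at a measured number. Compound 3 `CN1CCN(CCNCc2cn(-c3ccc(F)cc3F)nc2-c2ccc(N(C)C)cc2)CC1` has not yet been measured in this assay. It differs from compound 1 by dimethylamino in place of hydrogen on an aromatic carbon; the group sits para to a large group, so that phenyl becomes 4-(dimethylamino)phenyl. Going by the values given here, no measured step of this kind is known here, and compound 3 is expected to stay near compound 1, with a step of small size or none beyond the scatter, because compound 1 sits at the limit of > 20000 nM in this assay, at which 1 of the 2 values shown sits. The expected step is an at least 1.3-fold lower number from compound 1 to compound 3 (0.12 log units; that floor lies within the scatter). Compound 3 is estimated to give about 15000 nM in this assay, between 4000 nM and 40000 nM.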

Compound 3, half-maximal cytotoxic concentration: > 20000 nM
Compound 3: a limit, no number; the forecaster's own chance of this, stated with the estimate: 50%; at least 1.3-fold (0.12 log units) between middle value and limit.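

Compound 1 and compound 3 both sit at a limit in this assay, not at a number, so no step can be read between them: the limit of > 20000 nM in this assay, at which 2 of the 3 values shown sit.

The compounds shown leave open whether dimethylamino in place of hydrogen on an aromatic carbon changes this read-out at all.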